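Quinolin-3-yl for 3,5-dimethoxyphenyl on the amine nitrogen

The source may report more compounds than this note shows. Statements on the series, on what has been measured and on what is new or still open speak of the compounds shown alone.

In a functional assay on HeLa cells (Homo sapiens) for cytotoxicity, read by MTT assay, with a stated time of 48 h (a higher number here means a weaker inhibitor, a lower number a stronger inhibitor), compound 3 `COc1cc(N/C=C\C(=O)c2c(-c3ccc(Cl)cc3)nc3ccccn23)cc(OC)c1` gives 14600 nM, the highest of the three numbers, against compound 1 `COc1ccc(-c2nc3ccccn3c2C(=O)/C=C\Nc2cc(OC)cc(OC)c2)cc1` at 4570 nM and compound 2 `O=C(/C=C\Nc1cnc2ccccc2c1)c1c(-c2ccccc2)nc2ccccn12` at 3080 nM. Compound 4 `O=C(/C=C\Nc1cnc2ccccc2c1)c1c(-c2ccc(Cl)cc2)nc2ccccn12` has quinolin-3-yl in place of 3,5-dimethoxyphenyl on an amine nitrogen. Going by the values given here, no measured step isolates this change. Among the compounds with values here, the only measured step, a 3.2-fold higher number from compound 1 to compound 3 (0.50 log units; beyond the scatter), is a modest one for chloro in place of methoxy, and it bears only indirectly. Compound 2 carries quinolin-3-yl without chloro and gives 3080 nM, so a lower number is expected. The expected step is a 2.4-fold lower number from compound 3 to compound 4 (0.39 log units; beyond the scatter). For compound 4 the estimated value is 6000 nM, with an expected range of 2000 nM to 16000 nM.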

Compound 4, half-maximal inhibitory concentration: 3720 nM
For compound 4 the middle estimate is 1.6-fold (0.21 log units) above the measured one; low and high end bracket the measured number.
By their numbers in this assay, from the lowest: compounds 2, 4 and 1 (each within the scatter of the next); then compound 3.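

In this assay, quinolin-3-yl in place of 3,5-dimethoxyphenyl on the amine nitrogen now has a directly measured step, a 3.9-fold lower number from compound 3 to compound 4 (0.59 log units; beyond the scatter), in the chloro series. With quinolin-3-yl in place, chloro in place of hydrogen on an aromatic carbon gives a 1.2-fold higher number from compound 2 to compound 4 (0.08 log units; within the scatter), so this pair is not separated by the assay. No data on hand explain either step.

Open, from the compounds shown here alone, is whether naphthalen-2-yl, which lacks the ring nitrogen, or pyridin-3-yl on the amine nitrogen would read like quinolin-3-yl. Also open, going by these compounds, is how fluoro or an amine on that aromatic carbon would read alongside quinolin-3-yl.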